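Replacing the hydroxy of compound 2: working notes

This account rests on a few compounds, and the source may have more. Where it says the series, first, only, none or still open, it means among the compounds named here.

Values so far in a functional assay on CNE-2 cells (Homo sapiens) for antiproliferative activity, read by sulforhodamine B assay, with a stated time of 48 h; a higher number here means a weaker inhibitor, a lower number a stronger inhibitor
compound 1 `COc1ccc(/C=C/C(=O)c2ccccc2-c2ccc(F)cc2)cc1` 53 nM
compound 2 `COc1ccc(/C=C/C(=O)c2ccccc2-c2ccc(F)cc2)cc1O` 87 nM

Going by the values given here, compound 2 gives 87 nM and stands within the scatter of compound 1, the only other measured compound, so the two cannot be told apart on these numbers.

Compound 3 `COc1ccc(/C=C/C(=O)c2ccccc2-c2ccc(F)cc2)cc1B(O)O` is the next to be read. Its change from compound 2 is a group of 3 heavy atoms (1 boron, 2 oxygen; no ring) in place of one oxygen atom, on an aromatic carbon and it falls on an aromatic carbon of a six-membered aromatic ring of carbon only, ortho to a methoxy group and meta to a large group.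

Among the compounds with values here, only one measured step bears on this: a 1.6-fold higher number from compound 1 to compound 2 (0.22 log units; within the scatter) for hydroxy in place of hydrogen on an aromatic carbon. Within the data shown here, no measured step covers the entering group itself, so the guidance is thin. With only a 1.6-fold higher number from compound 1 to compound 2 (0.22 log units; within the scatter) to go on, no step beyond the scatter is expected in this assay for this change.

The expected step is a 1.3-fold higher number from compound 2 to compound 3 (0.10 log units; within the scatter) as an estimate. For compound 3 the estimated value is 110 nM with an expected range of 35 nM to 350 nM in this series.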

Compound 3, half-maximal inhibitory concentration: 21 nM
For compound 3 the middle estimate is 5.2-fold (0.72 log units) above the measured one; measured number below the stated range.
By their numbers in this assay, from the lowest: compound 3; then compounds 1 and 2 (each within the scatter of the next).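

In this assay, this position, ortho to a methoxy group and meta to a large group, now separates its substituents: the boron-bearing group gives a 4.1-fold lower number from compound 2 to compound 3 (0.62 log units; beyond the scatter) when it replaces hydroxy. The same group also stands clear of plain hydrogen, with a 2.5-fold lower number from compound 1 to compound 3 (0.40 log units; beyond the scatter), whereas hydroxy in place of hydrogen gave only a 1.6-fold higher number from compound 1 to compound 2 (0.22 log units; within the scatter), which could not be told from the scatter. Among these three compounds, then, the position accepts a substituent without loss, and the read-out depends on which group sits there, though no measurement available here explains the lower number of compound 3.

As far as these compounds go, with one boron-bearing example, it remains open whether the step belongs to boron itself or would appear with any group of similar size at this place, and a carboxylic acid or a primary amide on the same aromatic carbon would separate the two readings. Also open, from the compounds shown here alone, is whether the boron-bearing group would give a step of similar size on a core carrying something other than the methoxy group beside it, such as an ethoxy group or a chlorine atom.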